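Carbamate ester swap, allyl to phenyl: cytotoxicity notes

The compounds below may be only part of what the source reports. "The series", "measured", "known", "first", "only" and "open" are said of these compounds alone.

Within the data shown here, compound 1 `C=CCOC(=O)Nc1ccc([Se]C#N)cc1` is one of two compounds so far measured in an ADME assay on BEAS-2B cells (Homo sapiens) for cytotoxicity, read by MTT assay, with a stated time of 72 h; a lower number here means a stronger inhibitor of growth, a higher number a weaker inhibitor of growth; compound 1 gives 47400 nM. Compound 2 `CCCCOC(=O)Nc1ccc([Se][Se]c2ccc(NC(=O)OCCCC)cc2)cc1` gives 49600 nM in this assay. Compound 1 holds the lower of the two numbers, but the nearest compound, compound 2, stands within the scatter of it, so the pair shows no separation that can be read as an order. Among the measured compounds shown here, no step between measured compounds is available: compound 2 differs from compound 1 in more than one place, and its number shows only that both sit in the same region of this assay.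

Compound 3 `N#C[Se]c1ccc(NC(=O)Oc2ccccc2)cc1` has not yet been measured in this assay. It differs from compound 1 in one place: phenyl in place of allyl on an oxygen next to a carbonyl group. For the measured compounds named here, nothing among the measured compounds covers this change, and the two numbers in hand lie close together, so no direction can be drawn from them. The expectation is that the step of a 1.2-fold lower number from compound 1 to compound 3 (0.07 log units; within the scatter) stays within the scatter, with no direction beyond it. Compound 3 is therefore estimated at 40000 nM, with a range from 15000 nM to 100000 nM.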

Compound 3, concentration for total growth inhibition: 38200 nM
Estimate against measurement, compound 3: 1.0-fold (0.02 log units) above; measured number inside the range.
By their numbers in this assay, from the lowest: compounds 3, 1 and 2 (each within the scatter of the next).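

In this assay, among these compounds, the change of allyl to phenyl on an oxygen next to a carbonyl group gives a 1.2-fold lower number from compound 1 to compound 3 (0.09 log units; within the scatter) and is the first single-place step, since compound 2 differs from compound 1 in more than one place and could only show that both sit in the same region. The step shows that this position can carry one six-membered aromatic ring of carbon only in place of a ringless group with a double bond, with no separation that can be read as an order. A single step across these two groups is all the position has so far, and no measurement of any property of these groups bears on the result.

Open, going by these compounds, is whether a group of another kind on this oxygen, such as a longer chain or a chain ending in an amine or a carboxylic acid, would move the number beyond the scatter in this assay. Also open, on these data alone, is whether the allyl to phenyl change would stay as quiet on a core other than that of compound 1, for instance one carrying the diselenide link of compound 2.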